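Aryl Variation on the Aromatic Nitrogen: Compound 3

The source may hold more compounds than are shown below. What is called first, only, known or untested is meant among the compounds shown, and "the series" means these compounds.

Working notes on the series. For the measured compounds named here, compound 2 `COc1cc2c(Oc3ccc(NC(=O)c4nn(-c5ccccc5Br)c(=O)c5ccccc45)cc3F)ccnc2cc1OCCCN1CCN(C)CC1` gives 400 nM in a functional assay on MKN-45 cells (Homo sapiens) for cytotoxicity, read by MTT assay, with a stated time of 72 h (on this read-out lower numbers stand for stronger inhibition and higher numbers for weaker inhibition), the higher of the two numbers measured so far; its nearest neighbour is compound 1 `COc1cc2c(Oc3ccc(NC(=O)c4nn(-c5ccc(F)cc5)c(=O)c5ccccc45)cc3F)ccnc2cc1OCCCN1CCN(C)CC1`, which in this assay gives 150 nM. Going by the values given here, the single measured step, a 2.7-fold higher number from compound 1 to compound 2 (0.43 log units; beyond the scatter), is the only guide for the aryl on the aromatic nitrogen. Compound 3 `COc1cc2c(Oc3ccc(NC(=O)c4nn(-c5ccc([N+](=O)[O-])cc5)c(=O)c5ccccc45)cc3F)ccnc2cc1OCCCN1CCN(C)CC1` is not yet measured; it differs from compound 2 by 4-nitrophenyl in place of 2-bromophenyl on an aromatic nitrogen. Compound 3 thus carries 4-nitrophenyl where compound 1 carries 4-fluorophenyl and compound 2 carries 2-bromophenyl. Among the compounds with values here, the nitro group is new to the series and its own contribution is unknown, so the expectation rests on the one measured step: moving away from 2-bromophenyl is expected to give a modest step toward lower numbers in this assay, about the size of the measured step but with wide uncertainty. Compound 3 is therefore expected to give 200 nM in this assay, within 70 nM to 600 nM, which means an expected step of a 2.0-fold lower number from compound 2 to compound 3 (0.30 log units; within the scatter).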

Compound 3, half-maximal inhibitory concentration: 1320 nM
Estimate against measurement, compound 3: 6.6-fold (0.82 log units) below; measured number outside the range, above it.
By their numbers in this assay, from the lowest: compound 1; then compound 2; then compound 3.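

In this assay the aryl on the aromatic nitrogen proves sensitive to more than the placement of its substituent: 4-nitrophenyl gives the highest number of the three, with a 3.3-fold higher number from compound 2 to compound 3 (0.52 log units; beyond the scatter) and, for nitro in place of fluoro on an aromatic carbon, an 8.8-fold higher number from compound 1 to compound 3 (0.94 log units; beyond the scatter) as the steps, both beyond the scatter. Compounds 1 and 3 carry their groups in the same placement yet stand at the two ends of the order, so that placement alone does not secure a low number, and the 2-bromophenyl of compound 2 falls between them. No measurement available here bears on why the numbers move in this way.

The compounds shown leave open how an unsubstituted phenyl, or a methoxy group or an amine on that ring, would stand against the 4-fluorophenyl of compound 1. Compound 2 differs from compound 1 in both the halogen and its placement, so the contribution of each to that step remains unseparated.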